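Thiophene swap on the core of compound 1

The source may report more compounds than this note shows. Statements on the series, on what has been measured and on what is new or still open speak of the compounds shown alone.

Measured so far in a functional assay on cells (Cancer cell lines, Homo sapiens) for inhibition; a lower number here means a stronger inhibitor of growth, a higher number a weaker inhibitor of growth:
- compound 1 `N=C(N)N/N=C/c1c(-c2cc(Cl)sc2Cl)nc2n1CCS2`: 10000 nM
- compound 2 `N=C(N)N/N=C/c1c(-c2ccsc2)nc2sccn12`: 14800 nM
- compound 3 `Cc1cn2c(/C=N/NC(=N)N)c(-c3cccs3)nc2s1`: 4270 nM

On these numbers, compound 1 lies within the scatter of compound 2, and both stand beyond the scatter above compound 3. Compound 4 `N=C(N)N/N=C/c1c(-c2ccsc2)nc2n1CCS2` keeps the core of compound 1 and carries thiophen-3-yl in place of 2,5-dichlorothiophen-3-yl on an aromatic carbon. Within the data shown here, no measured pair isolates this change. Compound 2 also carries thiophen-3-yl, on a different core, and gives 14800 nM. A small rise in this assay, within the scatter, is therefore expected. The expected change is a 1.2-fold higher number from compound 1 to compound 4 (0.08 log units; within the scatter). The estimated value for compound 4 is 12000 nM, with an expected range of 5000 nM to 30000 nM.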

Compound 4, concentration for 50% growth inhibition: 28200 nM
Compound 4: the middle estimate sits 2.4-fold (0.37 log units) below what was measured; measured number inside the range.
By their numbers in this assay, from the lowest: compound 3; then compounds 1, 2 and 4 (each within the scatter of the next, the first and the last beyond it).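

On the core of compound 1, this aromatic carbon responds to the substituent on the thiophene: in this assay, thiophen-3-yl in place of 2,5-dichlorothiophen-3-yl gives a 2.8-fold higher number from compound 1 to compound 4 (0.45 log units; beyond the scatter), a modest step beyond the scatter. Among these compounds, this is the first matched comparison, and on this core the two chlorine atoms go with the lower number. No supporting data bear on why the step arises.

Which chlorine carries the step remains open, as does whether a 2-chlorothiophen-3-yl or 5-chlorothiophen-3-yl group would stand with compound 1 or compound 4. A phenyl group at this carbon is also untested among the compounds shown, and whether the step holds on other cores remains open.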